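The source may hold more compounds than are shown below. What is called first, only, known or untested is meant among the compounds shown, and "the series" means these compounds.

Measured in a functional assay on SK-BR-3 cells (Homo sapiens) for cytotoxicity, read by resazurin assay; a lower number here means a stronger inhibitor, a higher number a weaker inhibitor:
- compound 1 `C#Cc1cccc(Nc2ncnc3cc(NC(=O)c4ccc(C(=O)Nc5ccccc5N)s4)ccc23)c1`: 33000 nM
- compound 2 `C#Cc1cccc(Nc2ncnc3ccc(NC(=O)c4ccc(C(=O)Nc5ccccc5N)cc4)cc23)c1`: > 50000 nM (a limit, not a number)
- compound 3 `C#Cc1cccc(Nc2ncnc3ccc(S(=O)(=O)n4ccc(/C=C/C(=O)Nc5ccccc5N)c4)cc23)c1`: 27000 nM

Among the measured compounds shown here, compound 3, at 27000 nM, lies within the scatter of compound 1, the only other compound with a number. Compound 4 `C#Cc1cccc(Nc2ncnc3ccc(S(=O)(=O)n4ccc(/C=C/C(=O)NO)c4)cc23)c1` is not yet measured. It differs from compound 3 by hydroxy in place of 2-aminophenyl on an amide-type nitrogen, with hydroxy in place of 2-aminophenyl on an amide-type nitrogen. For the measured compounds named here, every compound measured so far keeps the 2-aminophenyl group, so no measured pair tests this change and the expectation is a judgement. A clear move to a lower number in this assay is expected, beyond the scatter. The expected change is a 9.0-fold lower number from compound 3 to compound 4 (0.95 log units; beyond the scatter). For compound 4 the estimated value is 3000 nM, with an expected range of 300 nM to 20000 nM.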

Compound 4, half-maximal inhibitory concentration: 190 nM
Beside the measured number, compound 4's estimate is 16-fold (1.20 log units) above it; measured number outside the range, below it.
By their numbers in this assay, from the lowest: compound 4; then compounds 3 and 1 (each within the scatter of the next). At a limit, above all of these: compound 2.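

Hydroxy in place of 2-aminophenyl on an amide-type nitrogen gives a 140-fold lower number from compound 3 to compound 4 (2.15 log units; beyond the scatter) in this assay. Among the compounds shown here, all earlier compounds keep 2-aminophenyl, so this is the first measured test of this place, and the large step shows that the group there strongly affects the read-out. No measured information here bears on the cause of the step.

On these data alone, whether the same change carries over to compound 1 and compound 2 remains open. Also open, as far as these compounds go, is how a carboxylic acid or a methoxyamide would compare with the hydroxycarbamoyl group of compound 4.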